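Compound 3 to compound 4: same atoms, joined differently

The source may report more compounds than this note shows. Statements on the series, on what has been measured and on what is new or still open speak of the compounds shown alone.

- Compound 1 `CCOc1cc2oc(=O)n(CCC(=O)O)c2cc1Cl`: < 10 nm/s
- Compound 2 `C[C@@H](Oc1cc2oc(=O)n(CCC(=O)O)c2cc1Cl)c1ncco1`: < 3 nm/s
- Compound 3 `Cc1ccnc([C@@H](C)Oc2cc3oc(=O)n(CCC(=O)O)c3cc2Cl)c1`: < 3 nm/s

In a physicochemical assay for permeability, using PAMPA (on this read-out higher numbers stand for higher permeability and lower numbers for lower permeability), compound 1 gives < 10 nm/s, which is a limit and not a number. Compound 2 gives < 3 nm/s, also a limit. Compound 3 stands at the limit of < 3 nm/s in this assay, at which 2 of the 3 values shown sit.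

Compound 4 `Cc1cccc([C@@H](C)Oc2cc3oc(=O)n(CCC(=O)O)c3cc2Cl)n1` has not yet been measured. It differs from compound 3 in one place: 6-methylpyridin-2-yl in place of 4-methylpyridin-2-yl on a saturated chain carbon bound to an oxygen on an aromatic ring and a saturated chain carbon. In words, 6-methylpyridin-2-yl stands in place of 4-methylpyridin-2-yl on a saturated chain carbon bound to an oxygen on an aromatic ring and a saturated chain carbon. The two compounds have the same atoms, joined differently.

Two measured steps lead to compound 3 and so bear on this change: a step that the two limits leave unreadable from compound 1 to compound 3 and a step that the two limits leave unreadable from compound 2 to compound 3. Neither gives a size to build on. The expectation therefore rests on compound 3, whose < 3 nm/s is a limit. No step beyond the usual scatter is expected in this assay, in either direction. The expected step is a step that the limit leaves unreadable from compound 3 to compound 4. For compound 4 the estimate is 2 nm/s, within an expected range from 1 nm/s to 5 nm/s.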

Compound 4, apparent permeability: 21 nm/s
Compound 4: the middle estimate sits 11-fold (1.02 log units) below what was measured, and the stated range ends below it.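

The steps among compound 1, compound 2 and compound 3 cannot be read, and so this assay had given no size for any change at this position. The swap of 4-methylpyridin-2-yl for 6-methylpyridin-2-yl now gives an at least 7.0-fold higher number from compound 3 to compound 4 (0.84 log units; beyond the scatter) and shows that, on this saturated chain carbon, the number can move beyond the scatter even when the group keeps the same atoms, joined differently. Going by these compounds alone, the same group gives an at least 7.0-fold higher number from compound 2 to compound 4 (0.84 log units; beyond the scatter) when it replaces 1,3-oxazol-2-yl and an at least 2.1-fold higher number from compound 1 to compound 4 (0.32 log units; beyond the scatter) when it replaces hydrogen, which makes compound 4 the only one of the four compounds with a number and not a limit.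

Nothing among the data shown explains why joining the same atoms differently moves this number. Going by these compounds, the full size of each step stays open behind the limits of the other three compounds, and it is also open how the number would respond on this same carbon to a plain pyridin-2-yl or a 6-ethylpyridin-2-yl, which would test whether the gain belongs to 6-methylpyridin-2-yl alone.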